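Sulfur aryl exchange from compound 3 to compound 4

The source may report more compounds than this note shows. Statements on the series, on what has been measured and on what is new or still open speak of the compounds shown alone.

Measured so far in a functional assay on HCT-116 cells (Homo sapiens) for antiproliferative activity, read by CCK-8 assay, with a stated time of 72 h (a higher number here means a weaker inhibitor, a lower number a stronger inhibitor), for the series:
- compound 1 `COc1ccc(SCc2ccc(C(=O)Nc3ccccc3N)cc2)cc1` gives 1640 nM as its value
- compound 2 `CCc1ccc(SCc2ccc(C(=O)Nc3ccccc3N)cc2)cc1` gives 1740 nM as its value
- compound 3 `Nc1ccccc1NC(=O)c1ccc(CSc2cccc(F)c2)cc1` gives 2870 nM as its value

Compound 3 sits within the scatter of the other two, with a 1.6-fold higher number from compound 2 to compound 3 (0.22 log units; within the scatter) and a 1.8-fold higher number from compound 1 to compound 3 (0.24 log units; within the scatter) as its steps. The change now in view, 4-methylphenyl in place of 3-fluorophenyl on a sulfur, is 4-methylphenyl in place of 3-fluorophenyl on a sulfur and gives compound 4 `Cc1ccc(SCc2ccc(C(=O)Nc3ccccc3N)cc2)cc1` as the next entry. Among the compounds with values here, no measured pair makes this exact exchange. The two steps above also alter the group on the sulfur, and both stay within the scatter. So does a 1.1-fold higher number from compound 1 to compound 2 (0.03 log units; within the scatter) in this small set. Three compounds are thin evidence, but on them no step beyond the scatter is expected in this assay for compound 4. The estimated step is a 1.6-fold lower number from compound 3 to compound 4 (0.21 log units; within the scatter) and would stay within the scatter. For compound 4 the expected value is 1750 nM with an estimated range from 1000 nM to 3000 nM in this read-out.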

Compound 4, half-maximal inhibitory concentration: 2630 nM
Beside the measured number, compound 4's estimate is 1.5-fold (0.18 log units) below it; measured number inside the range.
By their numbers in this assay, from the lowest: compounds 1, 2, 4 and 3 (each within the scatter of the next).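

In this assay, 4-methylphenyl on the sulfur reads level with 3-fluorophenyl (a 1.1-fold lower number from compound 3 to compound 4 (0.04 log units; within the scatter)), so a fluorine-bearing group and a methyl-bearing group are not told apart here. The neighbouring exchanges also stay within the scatter: hydrogen in place of methyl on the ethyl chain (a 1.5-fold higher number from compound 2 to compound 4 (0.18 log units; within the scatter)) and methyl in place of methoxy (a 1.6-fold higher number from compound 1 to compound 4 (0.21 log units; within the scatter)). Across these four compounds, the aryl group on the sulfur has therefore shown no step beyond the scatter, and no supporting data bear on this result.

From the compounds shown here alone, whether an aryl group carrying an amine, a carboxylic acid or a longer chain would move the number beyond the scatter remains open. Also open, going by these compounds, is whether a pyridine ring on the sulfur would leave the number level with these four.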